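Homologation of the acid in an indane sulfonamide series

The compounds below may be only part of what the source reports. "The series", "measured", "known", "first", "only" and "open" are said of these compounds alone.

Measured so far in a functional assay on aorta for antagonist activity at thromboxane A2 receptor (Rattus norvegicus); on this read-out higher numbers stand for weaker inhibition and lower numbers for stronger inhibition:
- compound 1, `O=C(O)c1ccc2c(c1)CC(CNS(=O)(=O)c1ccc(Cl)cc1)C2`: 26.3 nM
- compound 2, `O=C(O)c1ccc2c(c1)CC(CCNS(=O)(=O)c1ccc(Cl)cc1)C2`: 66.1 nM
- compound 3, `O=C(O)c1ccc2c(c1)CC(CCCCNS(=O)(=O)c1ccc(Cl)cc1)C2`: the reading is a limit only, > 479 nM

Compound 2 gives the higher of the two real numbers; compound 1 sits lower by a margin beyond the scatter. The only further point is the limit of compound 3, recorded as the limit of > 479 nM in this assay, at which 1 of the 3 values shown sits.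

Compound 4, `O=C(O)Cc1ccc2c(c1)CC(CCNS(=O)(=O)c1ccc(Cl)cc1)C2`, differs from compound 2 in one place: carboxymethyl in place of carboxy on an aromatic carbon. Among the measured compounds shown here, no measured pair mirrors this change, so the size of the step rests on judgment alone. The measured pairs all change the linker to the sulfonamide and read as losses with length; moving the acid out by one carbon is a different change, and a modest loss beyond the scatter is expected rather than a gain. The expected step is a 2.3-fold higher number from compound 2 to compound 4 (0.36 log units; beyond the scatter) in this assay. Compound 4 is therefore estimated at 150 nM, with a range from 40 nM to 600 nM.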

Compound 4, half-maximal inhibitory concentration: 31.6 nM
Compound 4: middle estimate off by 4.7-fold (0.68 log units), on the high side, and the stated range ends above it.
By their numbers in this assay, from the lowest: compounds 1 and 4 (each within the scatter of the next); then compound 2. At a limit, above all of these: compound 3.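

In this assay, the aromatic carbon that carries the acid accepts a longer group, and carboxymethyl in place of carboxy gives a modest gain (a 2.1-fold lower number from compound 2 to compound 4 (0.32 log units; beyond the scatter)). Among the compounds shown here, the earlier compounds changed only the chain to the sulfonamide, where the number rises from compound 1 at 26.3 nM to compound 2 at 66.1 nM, so compound 4 is the first to show that adding one carbon can lower the number, and at a different place on the molecule. Nothing on hand bears on the cause of this step.

Still open, going by these compounds, is whether a longer chain on the acid, such as carboxyethyl, extends the gain or reverses it. Also open, on these data alone, is whether a tetrazole can stand in place of the carboxylic acid on this aromatic carbon.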